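A few compounds are considered here, and "the series" means these few. Any claim that something is new, unique, unknown or untested is made for them only; others in the source may bear on it.

In a functional assay on RAW264.7 cells (Mus musculus) for inhibition, with a stated time of 30 min (on this read-out lower numbers stand for stronger inhibition and higher numbers for weaker inhibition), compound 3 `C=C1C(=O)OC[C@H]1CCOC(=O)Nc1ccccc1` gives 390 nM. The other two measured compounds sit close by: compound 1 `C=C1C(=O)OC[C@H]1CCOC(=O)Nc1ccc(C(=O)OCCCC)cc1` gives 430 nM in this assay, and compound 2 `C=C1C(=O)OC[C@H]1CCOC(=O)Nc1ccc(Br)cc1` gives 350 nM, so the number for compound 3 lies among theirs with all three inside the usual scatter of one another. The three steps between them confirm this: a 1.2-fold lower number from compound 1 to compound 2 (0.09 log units; within the scatter), a 1.1-fold lower number from compound 1 to compound 3 (0.04 log units; within the scatter) and a 1.1-fold higher number from compound 2 to compound 3 (0.05 log units; within the scatter).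

Compound 4 `C=C1C(=O)OC[C@H]1CCOC(=O)Nc1ccc(OC)cc1` differs from compound 3 by methoxy in place of hydrogen on an aromatic carbon. The measured steps that bear on this place are the exchanges at the same aromatic carbon, where bromo, butoxycarbonyl and hydrogen gave numbers that did not move beyond the scatter. On that basis the account expects no step beyond the scatter in this assay for compound 4 either, the estimated step being a 1.0-fold lower number from compound 3 to compound 4 (0.01 log units; within the scatter). For compound 4 the estimated value in this assay is 380 nM, with a range from 200 nM to 750 nM.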

Compound 4, half-maximal inhibitory concentration: 710 nM
For compound 4 the middle estimate is 1.9-fold (0.27 log units) below the measured one, within the range that was stated.
By their numbers in this assay, from the lowest: compounds 2, 3, 1 and 4 (each within the scatter of the next, the first and the last beyond it).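

In this assay, among the compounds shown here, the exchange of bromo for methoxy on this aromatic carbon gives the first step at this place that lies beyond the scatter (a 2.0-fold higher number from compound 2 to compound 4 (0.31 log units; beyond the scatter)), a modest one towards weaker inhibition. Methoxy stays within the scatter of both hydrogen (a 1.8-fold higher number from compound 3 to compound 4 (0.26 log units; within the scatter)) and butoxycarbonyl (a 1.7-fold higher number from compound 1 to compound 4 (0.22 log units; within the scatter)), so the position is not wholly indifferent to what it carries, yet only this one pair of compounds separates. Nothing measured here accounts for the difference between methoxy and bromo.

From the compounds shown here alone, whether an amine, a carboxylic acid or a longer alkoxy chain on this carbon would move the number further stays open. Going by these compounds, it is also open whether other groups would fall with methoxy or with bromo, since two compounds alone mark this gap.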